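This account rests on a few compounds, and the source may have more. Where it says the series, first, only, none or still open, it means among the compounds named here.

In an ADME assay on H1-HeLa cells (Homo sapiens) for cytotoxicity, read by MTT assay, with a stated time of 3 days (on this read-out higher numbers stand for lower toxicity in this test and lower numbers for higher toxicity in this test), two compounds sharing one core have been measured so far. Compound 1 `CCOC(=O)c1sc2cc(Oc3ccnc(C(=O)NC)c3)ccc2c1C` gives 50900 nM, and compound 2 `CNC(=O)c1cc(Oc2ccc3c(C)c(C(=O)OC(C)C)sc3c2)ccn1` gives 18100 nM. That is the lower of the two numbers, and so the higher toxicity in this test. The next compound, compound 3 `CCCOC(=O)c1sc2cc(Oc3ccnc(C(=O)NC)c3)ccc2c1C`, has the same atoms as compound 2, joined differently: propyl in place of isopropyl on an oxygen next to a carbonyl group. Within the data shown here, only one measured step bears on this change. That step, a 2.8-fold lower number from compound 1 to compound 2 (0.45 log units; beyond the scatter), was modest and came from methyl in place of hydrogen on the same chain, so only a small shift is expected here. A single step cannot establish a pattern, and the direction is uncertain, though a slightly higher number seems the likelier outcome. The expected size is a 1.2-fold higher number from compound 2 to compound 3 (0.08 log units; within the scatter), which would probably not stand out from the scatter. The estimate for compound 3 is 22000 nM, with an expected range from 9000 nM to 55000 nM.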

Compound 3, half-maximal cytotoxic concentration: 37400 nM
Compound 3: the middle estimate sits 1.7-fold (0.23 log units) below what was measured, within the range that was stated.
By their numbers in this assay, from the lowest: compound 2; then compounds 3 and 1 (each within the scatter of the next).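

In this assay, swapping isopropyl for propyl on an oxygen next to a carbonyl group leaves the atoms unchanged and alters only how the carbons are joined, yet it gives a 2.1-fold higher number from compound 2 to compound 3 (0.32 log units; beyond the scatter) and so lies beyond the scatter, which shows that at this position the arrangement of the chain can matter and not only its carbon count. Both compound 2 and compound 3 carry one more methyl than compound 1, but they differ in where it sits: the isopropyl chain gives a 2.8-fold lower number from compound 1 to compound 2 (0.45 log units; beyond the scatter) beyond the scatter, while the propyl chain gives a 1.4-fold lower number from compound 1 to compound 3 (0.13 log units; within the scatter) within the scatter, so compound 3 cannot be told apart from compound 1 here, and among these three compounds only the isopropyl chain stands out. No measurement available here explains why the two chains differ.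

As far as these compounds go, three chains on one core are too few to show a trend, so it remains open how a butyl chain, a tert-butyl group or a cyclopropyl group on the same oxygen would read. From the compounds shown here alone, it is also open whether a carboxylic acid at this place would read differently, and whether the gap between propyl and isopropyl would recur on another core.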